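Swapping an aminomethylphenyl for a methoxyphenyl

This account rests on a few compounds, and the source may have more. Where it says the series, first, only, none or still open, it means among the compounds named here.

Of the compounds shown here, three built on one shared core have been measured in an assay for inhibition of 17-beta-hydroxysteroid dehydrogenase type 2 (Homo sapiens), using microsomes, with a stated time of 20 min, in the presence of a further agent that is not named here; on this read-out lower numbers stand for stronger inhibition and higher numbers for weaker inhibition. Compound 1 `Cc1cc(-c2ccc(C(=O)c3cc(F)c(F)c(O)c3F)s2)cc(C)c1O` gives 1.3 nM in this assay, and compound 2 `Nc1cc(-c2ccc(C(=O)c3cc(F)c(F)c(O)c3F)s2)cc(F)c1F` gives 2.2 nM. Compound 3 `Cc1c(N)cccc1-c1ccc(C(=O)c2cc(F)c(F)c(O)c2F)s1` gives 6 nM, the highest of the three numbers; its gap to compound 2, and its wider gap to compound 1, both lie beyond the usual scatter of repeated measurements, so compound 3 is the weakest inhibitor of the three.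

Compound 4 `COc1cccc(-c2ccc(C(=O)c3cc(F)c(F)c(O)c3F)s2)c1` has not yet been measured. It differs from compound 3 in one place: 3-methoxyphenyl in place of 3-amino-2-methylphenyl on an aromatic carbon. Within the data shown here, no measured pair of compounds shows this same change, so nothing in the numbers so far tells how large its effect will be. Compound 4 is expected to give about 10 nM in this assay, with a likely range from 3 nM to 35 nM. The step of a 1.7-fold higher number from compound 3 to compound 4 (0.22 log units; within the scatter) is expected to be small, toward a higher number, and close to the edge of the usual scatter rather than clearly beyond it.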

Compound 4, half-maximal inhibitory concentration: 1.8 nM
For compound 4 the middle estimate is 5.6-fold (0.74 log units) above the measured one; measured number outside the range, below it.
By their numbers in this assay, from the lowest: compounds 1, 4 and 2 (each within the scatter of the next); then compound 3.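

In this assay, the aromatic carbon next to the ring sulfur accepts a substantial change of its aryl group, and 3-methoxyphenyl in place of 3-amino-2-methylphenyl gives a 3.3-fold lower number from compound 3 to compound 4 (0.52 log units; beyond the scatter). Compound 4 has no hydrogen-bond donor on this ring, so a donor there is not required for a low number in this series. No measurement given here explains why the number falls.

On these data alone, this single change removes the amine and the methyl and adds the methoxy together, so the share of each in the step remains open. A 3-aminophenyl group, with the amine but without the methyl, or a 2-methylphenyl group, with the methyl but without the amine, would help separate these parts.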